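The source may hold more compounds than are shown below. What is called first, only, known or untested is meant among the compounds shown, and "the series" means these compounds.

Measured compounds:
compound 1 `O=S(=O)(/C=C/c1ccc(F)cc1)Cc1ccc(Nc2ncnc3ccccc23)cc1` gives 16000 nM
compound 2 `O=S(=O)(/C=C/c1ccc(Cl)cc1)Cc1ccc(Nc2ncnc3ccccc23)cc1` gives 52000 nM
compound 3 `O=S(=O)(/C=C/c1ccc(F)cc1Cl)Cc1ccc(Nc2ncnc3cc(Cl)ccc23)cc1` gives 15000 nM

All three were tested in a functional assay on MCF7 cells (Homo sapiens); a higher number here means a weaker inhibitor of growth, a lower number a stronger inhibitor of growth. Compound 2 and compound 1 share one core and differ in a single spot: fluoro in place of chloro on an aromatic carbon. That exchange brought a 3.3-fold lower number from compound 2 to compound 1 (0.51 log units; beyond the scatter). Compound 3 carries a different core; the difference between the two cores is not broken down here. In this assay compound 3 and compound 1 give numbers that lie within the scatter of each other, so neither can be ranked above the other, while compound 2 sits clearly higher than both.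

Compound 4 `O=S(=O)(/C=C/c1ccc(F)cc1F)Cc1ccc(Nc2ncnc3cc(Cl)ccc23)cc1` is not yet measured. It differs from compound 3 in one place: fluoro in place of chloro on an aromatic carbon. Among the measured compounds shown here, this is the same kind of change as the one from compound 2 to compound 1, but not the same: in the earlier pair the exchange sits para to a large group, whereas in compound 4 it sits ortho to a large group and meta to a fluoro group. Because the earlier exchange gave a 3.3-fold lower number from compound 2 to compound 1 (0.51 log units; beyond the scatter), a lowering is expected here too, but a smaller one, since the surroundings of the exchange are not the same; the expected step is a 1.9-fold lower number from compound 3 to compound 4 (0.27 log units; within the scatter). The estimated value for compound 4 in this assay is 8000 nM, with a likely range from 3000 nM to 30000 nM.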

Compound 4, concentration for 50% growth inhibition: > 100000 nM
Compound 4 was reported as a limit (the forecaster's own chance of this, stated with the estimate: 5%); middle value at least 12-fold (1.09 log units) away from the limit.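

In this assay, fluoro in place of chloro on an aromatic carbon brought an at least 6.6-fold higher number from compound 3 to compound 4 (0.82 log units; beyond the scatter), so the lowering seen with the same exchange in the earlier pair did not carry over to the core of compound 3: the same change on two cores in this assay, a 3.3-fold lower number (0.51 log units; beyond the scatter) from compound 2 to compound 1 and an at least 6.6-fold higher number (0.82 log units; beyond the scatter) from compound 3 to compound 4, at least 21-fold (1.33 log units) apart, beyond the scatter of two such steps Compound 4 gives > 100000 nM, which is a limit of the assay and not a number: the limit of > 100000 nM in this assay, at which 1 of the 4 values shown sits. The result shows that, in this series, the outcome of this exchange on one core is a poor guide to its outcome on another, but it does not show why, since the two pairs differ in their core and also in the surroundings of the exchange, where in compound 4 the new fluoro sits ortho to a large group and meta to a fluoro group.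

The compounds shown leave open whether the core or the surroundings of the exchange decide the outcome, and a matching pair on the core of compound 1 with the same 2-chloro-4-fluorophenyl to 2,4-difluorophenyl change could help to separate the two. Also open, from the compounds shown here alone, is how other groups in place of this chloro, such as a methyl, a methoxy or an amine, would behave on the core of compound 3.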